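The compounds below may be only part of what the source reports. "The series", "measured", "known", "first", "only" and "open" are said of these compounds alone.

Measured so far:
Compound 1, `CC1=CC(C)(C)Nc2c(C(=O)N[C@@H](C)/C=C/S(C)(=O)=O)cccc21`: > 25000 nM
Compound 2, `C[C@@H]1CC(C)(C)Nc2c(C(=O)NC/C=C/S(C)(=O)=O)cccc21`: 48000 nM

The read-out here is an ADME assay on Cortical neurone cells (Mus musculus) for cytotoxicity; on this read-out higher numbers stand for lower toxicity in this test and lower numbers for higher toxicity in this test. Compound 1 gives > 25000 nM in this assay, and that value is a limit of the assay rather than a measured number. In other words compound 1 stands at the limit of > 25000 nM in this assay, at which 1 of the 2 values shown sits. Compound 2, which shares the same core with a different pattern of methyl groups, gives 48000 nM in this assay. For the measured compounds named here, no step between compound 1 and compound 2 is worked out here; the two values simply show that both compounds sit at the low-toxicity end of what this test can see.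

Compound 3, `CC1=CC(C)(C)Nc2c(C(=O)NC/C=C/S(C)(=O)=O)cccc21`, has not yet been measured. It differs from compound 1 by one small change: hydrogen in place of methyl on a saturated chain carbon bound to an amide-type nitrogen and a double-bonded chain carbon. The methyl that leaves is a single carbon on the chain, and the rest of the molecule is untouched. Since compound 1 already sits at a limit, the step from compound 1 to compound 3 is expected to be small, with no direction beyond the scatter: a step that the limit leaves unreadable from compound 1 to compound 3. Compound 3 is therefore expected to give about 40000 nM in this assay, within a range from 20000 nM to 100000 nM.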

Compound 3, half-maximal cytotoxic concentration: > 25000 nM
Compound 3: no number, only a limit (the forecaster's own chance of this, stated with the estimate: 50%); the middle value does not contradict the limit.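

In this assay compound 3 gives > 25000 nM, which is a limit and not a number. For the compounds shown here, compound 1 also stands at a limit, so no step from it to compound 3 can be read: the limit of > 25000 nM in this assay, at which 2 of the 3 values shown sit. The compounds shown leave open whether hydrogen in place of methyl on that chain carbon changes the result in this assay at all.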